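Changing the terminal aryl group: compound 3 to compound 4

This account rests on a few compounds, and the source may have more. Where it says the series, first, only, none or still open, it means among the compounds named here.

Compound 3 `O=C(/C=C/c1ccc(Br)cc1)Nc1cc2c(Nc3ccc(F)c(Cl)c3)ncnc2cc1O[C@H]1CCOC1` gives 27500 nM in a functional assay on HeLa cells (Homo sapiens) for cytotoxicity, read by MTT assay, with a stated time of 72 h; a lower number here means a stronger inhibitor, a higher number a weaker inhibitor. Compound 1 `O=C(/C=C/c1ccc([N+](=O)[O-])cc1)Nc1cc2c(Nc3ccc(F)c(Cl)c3)ncnc2cc1O[C@H]1CCOC1` gives 27400 nM and compound 2 `COc1cc(/C=C/C(=O)Nc2cc3c(Nc4ccc(F)c(Cl)c4)ncnc3cc2O[C@H]2CCOC2)cc(OC)c1O` gives 27400 nM, so the three numbers sit together within the scatter: no change at the digits printed from compound 1 to compound 2 (within the scatter), a 1.0-fold higher number from compound 1 to compound 3 (0.00 log units; within the scatter) and a 1.0-fold higher number from compound 2 to compound 3 (0.00 log units; within the scatter). Compound 4 `O=C(/C=C/c1cc(Br)c(O)c(Br)c1)Nc1cc2c(Nc3ccc(F)c(Cl)c3)ncnc2cc1O[C@H]1CCOC1` is not yet measured; it differs from compound 3 by 3,5-dibromo-4-hydroxyphenyl in place of 4-bromophenyl on a double-bonded chain carbon bound to a double-bonded chain carbon. Each measured step changed this same group on the same double-bonded chain carbon, and none moved the number in this assay beyond the scatter. The present swap to 3,5-dibromo-4-hydroxyphenyl is therefore expected to leave the number essentially where it is, and the step is expected to read a 1.0-fold lower number from compound 3 to compound 4 (0.01 log units; within the scatter). For compound 4 the estimate in this assay is 27000 nM, with a range from 12000 nM to 60000 nM.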

Compound 4, half-maximal inhibitory concentration: 27700 nM
The estimate for compound 4 lay 1.0-fold (0.01 log units) below the measured number, within the range that was stated.
By their numbers in this assay, from the lowest: compounds 1, 2, 3 and 4 (each within the scatter of the next).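

In this assay the 3,5-dibromo-4-hydroxyphenyl group puts bromo and hydroxy on one aryl group, yet a 1.0-fold higher number from compound 3 to compound 4 (0.00 log units; within the scatter) and a 1.0-fold higher number from compound 2 to compound 4 (0.00 log units; within the scatter) and a 1.0-fold higher number from compound 1 to compound 4 (0.00 log units; within the scatter) all stay within the scatter. Across these four compounds, then, the aryl groups on this double-bonded chain carbon give no separable readings, even with a second bromine and a hydroxy added to 4-bromophenyl. No available evidence bears on why the numbers sit together.

Going by these compounds, whether any group at this place can move the number stays open. A dimethylamino group or a carboxylic acid on the aryl ring would test that.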